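The source may hold more compounds than are shown below. What is called first, only, known or untested is meant among the compounds shown, and "the series" means these compounds.

Three members of the series have numbers in a functional assay on CHO cells with adenosine receptor A1 (Homo sapiens) as the target, read by cAMP accumulation and immunoassay, with a stated time of 6 min, tested at 0.1 uM; on this read-out lower numbers stand for a stronger effect and higher numbers for a weaker effect at the one concentration tested. Compound 1 `Nc1scc(CN2CCN(c3ccc(Cl)cc3F)CC2)c1C(=O)c1ccc(Cl)cc1` gives -9.4%. Compound 2 `Nc1scc(CN2CCC(c3ccc(Cl)cc3)CC2)c1C(=O)c1ccc(Cl)cc1` gives -2.3%, and compound 3 `Nc1scc(CN2CCN(c3ccc(C(F)(F)F)cc3)CC2)c1C(=O)c1cccc(C(F)(F)F)c1` gives -11%. Compound 1 stands second highest of the three; compound 3 lies nearest to it and compound 2 furthest, and both gaps are within the scatter, so the three read alike at this concentration. Compound 4 `Nc1scc(CN2CCN(c3cccc4ccccc34)CC2)c1C(=O)c1ccc(Cl)cc1` is not yet measured. It differs from compound 1 by naphthalen-1-yl in place of 4-chloro-2-fluorophenyl on an amine nitrogen in a ring. Among the measured compounds shown here, no measured pair shows this change. With compound 1, compound 2 and compound 3 all sitting near zero in this assay, the step of a number 1.4 percentage points higher from compound 1 to compound 4 (within the scatter) is expected to be none beyond the scatter. Compound 4 is therefore estimated at -8%, with a range of -25% to 10%.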

Compound 4, a percentage reported as activity, at one concentration (the size of the read-out at that concentration, not a potency): 0%
Estimate against measurement, compound 4: 8 percentage points below, and the stated range covers the measured number.
By their numbers in this assay, from the lowest: compounds 3, 1, 2 and 4 (each within the scatter of the next, the first and the last beyond it).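

Naphthalen-1-yl in place of 4-chloro-2-fluorophenyl on an amine nitrogen in a ring gives a number 9.4 percentage points higher from compound 1 to compound 4 (within the scatter) in this assay. Among the compounds shown here, this is the first reading of a single change at this position, and exchanging the halogenated aryl group for a two-ring aromatic group without halogen leaves no step beyond the scatter at the one concentration tested. Nothing on hand accounts for this step.

Going by these compounds, whether a saturated group such as cyclohexyl, or a benzyl group, would read differently at this position stays open. On these data alone, the read-out at any other concentration also stays open.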